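Chloro for methoxy on the pendant aryl ring

The source may hold more compounds than are shown below. What is called first, only, known or untested is meant among the compounds shown, and "the series" means these compounds.

Compound 1 `Nc1nc(-c2ccc(Cl)cc2)cn1/N=C/c1cc2ccccc2nc1Cl`: > 50000 nM
Compound 2 `Cc1ccc2nc(Cl)c(/C=N/n3cc(-c4ccccc4)nc3N)cc2c1`: 48100 nM
Compound 3 `COc1ccc(-c2cn(/N=C/c3cc4cc(C)ccc4nc3Cl)c(N)n2)cc1`: 23600 nM

Three analogues have been tested in a functional assay on MDA-MB-231 cells (Homo sapiens) for cytotoxicity, read by MTT assay, with a stated time of 48 h; a higher number here means a weaker inhibitor, a lower number a stronger inhibitor. Compound 1 gives only a limit of the assay, > 50000 nM, so its value cannot be placed against the others. For the measured compounds named here, compound 2 gives 48100 nM and compound 3 gives 23600 nM, the lowest of the two numbers known. Going by the values given here, the one comparable step is a 2.0-fold lower number from compound 2 to compound 3 (0.31 log units; beyond the scatter), a modest gain.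

Compound 4 `Cc1ccc2nc(Cl)c(/C=N/n3cc(-c4ccc(Cl)cc4)nc3N)cc2c1` differs from compound 3 in one place: chloro in place of methoxy on an aromatic carbon. Among the compounds with values here, no measured step exchanges chloro for methoxy, so nothing bears on it directly. Compound 1 also carries the chloro group on the pendant ring, though on a different core, and it reaches only a limit (the limit of > 50000 nM in this assay, at which 1 of the 3 values shown sits). Taken together with the modest size of the step from compound 2 to compound 3, the number for compound 4 is expected to move back toward the weaker end rather than improve; the estimated step is a 1.9-fold higher number from compound 3 to compound 4 (0.28 log units; within the scatter). Compound 4 is therefore expected at about 45000 nM, with a range of 20000 nM to 100000 nM.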

Compound 4, half-maximal inhibitory concentration: 35200 nM
For compound 4 the middle estimate is 1.3-fold (0.11 log units) above the measured one; measured number inside the range.
By their numbers in this assay, from the lowest: compounds 3, 4 and 2 (each within the scatter of the next, the first and the last beyond it). At a limit, above all of these: compound 1.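

In this assay, chloro at this position, para to a large group, gives a 1.5-fold higher number from compound 3 to compound 4 (0.17 log units; within the scatter) against methoxy and a 1.4-fold lower number from compound 2 to compound 4 (0.14 log units; within the scatter) against hydrogen. Compound 4 therefore lies within the scatter of both compound 2 and compound 3, although the step between those two lies beyond it, so chloro cannot be ranked against either group. Compound 1 stands at a limit, so the step for the methyl on the core, an at least 1.4-fold lower number from compound 1 to compound 4 (0.15 log units; that floor lies within the scatter), is only a floor: the limit of > 50000 nM in this assay, at which 1 of the 4 values shown sits.

Still open, going by these compounds, is whether an amine, a carboxylic acid or a longer chain at this position would move the number beyond the scatter of compound 3. On these data alone, how far the methyl on the core counts, with a number on both sides of the step, also stays open.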